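Removing bromo from the thiophene of a diphenylmethyl sulfoxide

The source may hold more compounds than are shown below. What is called first, only, known or untested is meant among the compounds shown, and "the series" means these compounds.

The measured compounds:
compound 1, `COC1NN=C(C[S+]([O-])C(c2ccccc2)c2ccccc2)S1`, 108000 nM
compound 2, `[O-][S+](Cc1ccsc1Br)C(c1ccccc1)c1ccccc1`, 29300 nM

Both compounds share the diphenylmethyl sulfoxide core and differ only in the five-membered ring attached through the methylene. In an assay on HEK293 cells for inhibition of sodium-dependent dopamine transporter (Homo sapiens), read by scintillation counting, with stated times of 5 min and 1 min (on this read-out lower numbers stand for stronger inhibition and higher numbers for weaker inhibition), compound 1 gives 108000 nM, and compound 2 gives 29300 nM, the lowest of the two numbers, with a 3.7-fold lower number from compound 1 to compound 2 (0.57 log units; beyond the scatter) separating them.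

Compound 3, `[O-][S+](Cc1ccsc1)C(c1ccccc1)c1ccccc1`, has not yet been measured. Its difference from compound 2 is hydrogen in place of bromo on an aromatic carbon. For the measured compounds named here, the only measured step, from compound 1 to compound 2, exchanges one whole ring for another and therefore says nothing direct about removing a bromo from the thiophene; no step in this small set bears on the change itself. Without guidance, the expected step in this assay is small, and its direction is uncertain.

Compound 3 is therefore estimated at 40000 nM, between 15000 nM and 110000 nM, which corresponds to an expected 1.4-fold higher number from compound 2 to compound 3 (0.14 log units; within the scatter).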

Compound 3, half-maximal inhibitory concentration: 3000 nM
Estimate against measurement, compound 3: 13-fold (1.12 log units) above; the measured number lies below the stated range.
By their numbers in this assay, from the lowest: compound 3; then compound 2; then compound 1.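

In this assay the bromo on the aromatic carbon next to the ring sulfur proves to carry real weight: replacing it with hydrogen, going from 2-bromothiophen-3-yl to thiophen-3-yl, gives a 9.8-fold lower number from compound 2 to compound 3 (0.99 log units; beyond the scatter) and so isolates a change that the earlier whole-ring exchange could not separate. It also widens the distance from the non-aromatic ring of compound 1, since the brominated thiophene gave a 3.7-fold lower number from compound 1 to compound 2 (0.57 log units; beyond the scatter) while the unsubstituted one gives a 36-fold lower number from compound 1 to compound 3 (1.56 log units; beyond the scatter) and makes compound 3 the lowest of the series, with both of its steps printed as beyond the scatter. No measurement offered here accounts for the effect of removing the bromo.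

As far as these compounds go, what remains open is whether this result belongs to bromo alone or to any group on that aromatic carbon, a question that a chloro, a fluoro or a methyl there would begin to answer. The compounds shown also leave unexplored what a group such as an amine or a carboxylic acid would do on the thiophene, and whether the two phenyl rings of the shared core tolerate any substitution.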